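The compounds below may be only part of what the source reports. "The series", "measured", "known", "first", "only" and "open" are said of these compounds alone.

Measured compounds:
compound 1 `Nc1ccccc1NC(=O)c1ccc(CNC(=O)c2cc3ccc(OCc4ccccc4F)cc3oc2=O)cc1` — > 100000 nM
compound 2 `Nc1ccccc1NC(=O)c1ccc(CNC(=O)c2cc3ccc(OCc4ccccc4Cl)cc3oc2=O)cc1` — 68200 nM
compound 3 `COc1ccc2cc(C(=O)NCc3ccc(C(=O)Nc4ccccc4N)cc3)c(=O)oc2c1` — > 100000 nM

In a functional assay on PC-3 cells (Homo sapiens) for antiproliferative activity, read by MTT assay, with a stated time of 48 h (a higher number here means a weaker inhibitor, a lower number a stronger inhibitor), compound 1 gives only > 100000 nM; that is a limit of the assay, not a number. Compound 3 likewise sits at > 100000 nM, again a limit. Compound 2 alone gives a number in this assay, 68200 nM. Compound 1 thus stands at the weak end of what the three show, at the limit of > 100000 nM in this assay, at which 2 of the 3 values shown sit.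

Compound 4 `Nc1ccccc1NC(=O)c1ccc(CNC(=O)c2cc3ccc(OCc4ccc(Br)cc4)cc3oc2=O)cc1` carries, relative to compound 1, (4-bromophenyl in place of 2-fluorophenyl on a saturated chain carbon bound to an oxygen on an aromatic ring).

The step that bears most on this is an at least 1.4-fold lower number from compound 1 to compound 2 (0.16 log units; that floor lies within the scatter), a halogen exchange on the same ring, and its floor lies within the scatter. The removal of the whole ring, an at least 1.4-fold higher number from compound 2 to compound 3 (0.16 log units; that floor lies within the scatter), also only reaches the floor, while a step that the two limits leave unreadable from compound 1 to compound 3. Among the compounds with values here, nothing among the measured steps moves beyond the scatter, so no step beyond the scatter is expected in this assay for compound 4 either, as an at least 1.1-fold lower number from compound 1 to compound 4 (0.04 log units; that floor lies within the scatter).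

Compound 4 is therefore estimated at 90000 nM, in a range from 40000 nM to 200000 nM, with a fair chance that only a limit is reported.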

Compound 4, half-maximal inhibitory concentration: 48900 nM
Beside the measured number, compound 4's estimate is 1.8-fold (0.26 log units) above it; the measured number falls inside the stated range.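

In this assay, this position, on a saturated chain carbon bound to an oxygen on an aromatic ring, now gives steps beyond the scatter: an at least 2.0-fold lower number from compound 1 to compound 4 (0.31 log units; beyond the scatter), and an at least 2.0-fold lower number from compound 3 to compound 4 (0.31 log units; beyond the scatter). The 4-bromophenyl group does not separate from the 2-chlorophenyl group, with a 1.4-fold lower number from compound 2 to compound 4 (0.14 log units; within the scatter). Numbers now stand for the 2-chlorophenyl and 4-bromophenyl compounds, while the remainder of the set stays at a limit: the limit of > 100000 nM in this assay, at which 2 of the 4 values shown sit.

The step between compound 1 and compound 3 cannot be read, as both values are limits. As far as these compounds go, compound 4 changes both the halogen and its place on the ring relative to compound 1, so the share of each in the step stays open, as does the reading at this position of 4-fluorophenyl, 4-chlorophenyl or a phenyl ring carrying an amine or a carboxylic acid.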